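Swapping one five-membered ring for another in compound 3

The source may report more compounds than this note shows. Statements on the series, on what has been measured and on what is new or still open speak of the compounds shown alone.

Compound 2 `Cc1noc(C)c1-c1cnc(N)c(Oc2ccc(C(=O)Nc3cccc(Cl)c3)cc2)n1` carries a 3,5-dimethyl-1,2-oxazol-4-yl group on the shared core and a 3-chlorophenyl on the amide-type nitrogen. In a functional assay on HepG2 cells (Homo sapiens) for inhibition, read by MTT assay, with a stated time of 72 h (a higher number here means a weaker inhibitor, a lower number a stronger inhibitor), compound 2 gives 7300 nM. Among the compounds with values here, its only measured neighbour is compound 1 `Cc1noc(C)c1-c1cnc(N)c(Oc2ccc(C(=O)NC3CCCCC3)cc2)n1`, which has cyclohexyl on that nitrogen instead; in this assay compound 1 gives 5420 nM. Within the data shown here, of the two numbers known, the one for compound 2 is the larger, but the step of a 1.3-fold higher number from compound 1 to compound 2 (0.13 log units; within the scatter) lies within the scatter, so the two compounds cannot be told apart.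

Compound 3 `Cn1cc(-c2cnc(N)c(Oc3ccc(C(=O)Nc4cccc(Cl)c4)cc3)n2)cn1` keeps the 3-chlorophenyl amide and changes the five-membered ring: 1-methyl-1H-pyrazol-4-yl in place of 3,5-dimethyl-1,2-oxazol-4-yl on an aromatic carbon. Among the measured compounds shown here, no measured step touches this position; the single known step concerns the amide-type nitrogen and was within the scatter, so it offers no guide to the direction or size of this change. With nothing pointing either way, the expected step of no change at the digits printed from compound 2 to compound 3 (within the scatter) is none beyond the scatter. Compound 3 is therefore estimated to give 7300 nM in this assay, with a range from 2500 nM to 22000 nM.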

Compound 3, half-maximal inhibitory concentration: 21200 nM
The estimate for compound 3 lay 2.9-fold (0.46 log units) below the measured number, within the range that was stated.
By their numbers in this assay, from the lowest: compounds 1 and 2 (each within the scatter of the next); then compound 3.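

Within the data shown here, this is the first step that lies beyond the scatter: in this assay, 1-methyl-1H-pyrazol-4-yl in place of 3,5-dimethyl-1,2-oxazol-4-yl gives a 2.9-fold higher number from compound 2 to compound 3 (0.46 log units; beyond the scatter), so the ring on this aromatic carbon matters to the read-out, whereas the change on the amide-type nitrogen, a 1.3-fold higher number from compound 1 to compound 2 (0.13 log units; within the scatter), did not separate its two compounds. The step is modest, yet it shows that two groups can match in ring size, in number of ring hetero atoms and in hydrogen-bond donors and acceptors and still give distinguishable numbers, so these counts alone do not settle the outcome here. Nothing available bears on why the number rises with this swap.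

The compounds shown pair 1-methyl-1H-pyrazol-4-yl only with the 3-chlorophenyl amide, so it remains open whether the same step would appear with cyclohexyl on the amide-type nitrogen. Going by these compounds, it is also open how a group of another kind on this aromatic carbon, such as a phenyl ring or a simple amine, would compare with the two five-membered rings.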